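The source may hold more compounds than are shown below. What is called first, only, known or untested is meant among the compounds shown, and "the series" means these compounds.

Measured so far in a functional assay on HeLa cells (Homo sapiens) for antiproliferative activity, read by MTT assay, with a stated time of 72 h; on this read-out higher numbers stand for weaker inhibition and lower numbers for stronger inhibition:
Compound 1 `COc1cccc(N2C(=O)COc3ccc(-c4cnc(Cl)c(NS(=O)(=O)c5ccc(F)cc5)c4)cc32)c1`: > 40000 nM (a limit of the assay)
Compound 2 `O=C1COc2ccc(-c3cnc(Cl)c(NS(=O)(=O)c4ccc(F)cc4)c3)cc2N1c1ccc(F)cc1`: > 40000 nM (a limit of the assay)
Compound 3 `O=C1COc2ccc(-c3cnc(Cl)c(NS(=O)(=O)c4ccc(F)cc4)c3)cc2N1c1ccccc1`: 10300 nM

Among the compounds with values here, compound 3 holds the only true number of the three, at 10300 nM in this assay. Compound 1 and compound 2 both rest at the limit of > 40000 nM in this assay, at which 2 of the 3 values shown sit, and so give a limit, not a number.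

The next structure is compound 4 `O=C1COc2ccc(-c3cnc(Cl)c(NS(=O)(=O)c4ccc(F)cc4)c3)cc2N1C1CC1`, with cyclopropyl in place of phenyl on an amide-type nitrogen in a ring, three ring bonds from the ring oxygen: cyclopropyl in place of phenyl on an amide-type nitrogen in a ring.

Within the data shown here, two measured steps touch this group: an at least 3.8-fold lower number from compound 1 to compound 3 (0.58 log units; beyond the scatter) and an at least 3.8-fold lower number from compound 2 to compound 3 (0.58 log units; beyond the scatter). Both lie beyond the scatter, but each gives only a bound on the size, and each removes a substituent from the phenyl without replacing the phenyl itself. The remaining step, a step that the two limits leave unreadable from compound 1 to compound 2, cannot be read. The group on this nitrogen therefore matters in compound 1 and compound 2, but no measurement shows what a non-aromatic group does there.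

No direction is favoured in this assay, and the expected change is a 1.0-fold lower number from compound 3 to compound 4 (0.01 log units; within the scatter), with wide uncertainty. For compound 4 the estimated value is 10000 nM, with an expected range from 2500 nM to 40000 nM.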

Compound 4, half-maximal inhibitory concentration: 7180 nM
Beside the measured number, compound 4's estimate is 1.4-fold (0.14 log units) above it, and the stated range covers the measured number.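

In this assay, the amide-type nitrogen in the ring does not need an aromatic group to keep a measurable value: a 1.4-fold lower number from compound 3 to compound 4 (0.16 log units; within the scatter). Cyclopropyl, a three-membered non-aromatic ring with 3 heavy atoms, therefore cannot be told apart from phenyl, with 6 heavy atoms, at this position. The substituted phenyls separate from cyclopropyl, with an at least 5.5-fold lower number from compound 2 to compound 4 (0.74 log units; beyond the scatter) and an at least 5.5-fold lower number from compound 1 to compound 4 (0.74 log units; beyond the scatter), and these two steps give only bounds on the size, as compound 1 and compound 2 each stand at a limit of the assay and not at a number: the limit of > 40000 nM in this assay, at which 2 of the 4 values shown sit.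

Among the four compounds, only the 4-fluorophenyl and 3-methoxyphenyl groups separate from the rest, so the data point to the substituents on the phenyl rather than to the phenyl itself as the feature that matters here, though two examples are too few to give a rule. Still open, on these data alone, is whether a plain chain such as ethyl, a saturated ring larger than cyclopropyl such as cyclohexyl, or a chain ending in an amine or a carboxylic acid on this nitrogen would move the value beyond the scatter from compound 3 and compound 4.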